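Chloro in place of hydrogen on the phenyl of compound 2

The compounds below may be only part of what the source reports. "The series", "measured", "known", "first", "only" and "open" are said of these compounds alone.

Compound 2 `C=C1CC[C@@H]2[C@](C)(COC(=O)c3cccnc3)[C@H](OC(=O)c3cccnc3)CC[C@@]2(C)[C@@H]1/C=C/C1=C/C(=C\c2ccccc2)OC1=O` stands highest of the two numbers measured in an assay on isolated protein for inhibition of Maltase-glucoamylase (Homo sapiens), tested at 100 uM (a higher number here means more inhibition at the concentration tested (going by the name of the read-out), a lower number less inhibition), where compound 2 gives 100%. Compound 1 `C=C1CC[C@@H]2[C@](C)(COC(=O)c3cccnc3)[C@H](OC(=O)c3cccnc3)CC[C@@]2(C)[C@@H]1/C=C/C1=C/C(=C\C(C)=C\CCC/C=C/C)OC1=O` gives 68.9% in this assay; the step of a number 31.1 percentage points higher from compound 1 to compound 2 (beyond the scatter) is the only one measured and is large. Compound 3 `C=C1CC[C@@H]2[C@](C)(COC(=O)c3cccnc3)[C@H](OC(=O)c3cccnc3)CC[C@@]2(C)[C@@H]1/C=C/C1=C/C(=C\c2ccc(Cl)cc2)OC1=O` differs from compound 2 by chloro in place of hydrogen on an aromatic carbon, the same difference read one bond further out being phenyl to 4-chlorophenyl. Going by the values given here, no measured step bears directly on this change: the step from compound 1 to compound 2 concerns the ring against the chain, not a substituent on the ring. Compound 2 already sits at the top of the read-out, so compound 3 is expected to stay near it, with the step of a number 5 percentage points lower from compound 2 to compound 3 (within the scatter) expected to lie within the scatter. Compound 3 is therefore estimated at 95%, range 80% to 100%.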

Compound 3, a percentage reported as inhibition, at one concentration (the size of the read-out at that concentration, not a potency): 100%
Compound 3: middle estimate off by 5 percentage points, on the low side; the range from low to high includes it.
By their numbers in this assay, from the lowest: compound 1; then compounds 2 and 3 (each within the scatter of the next).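

In this assay, chloro in place of hydrogen on the aromatic carbon para to a large group leaves the read-out in place, with no change at the digits printed from compound 2 to compound 3 (within the scatter) as the printed step. The advantage of the ring over the chain also survives this substitution, since a number 31.1 percentage points higher from compound 1 to compound 3 (beyond the scatter) matches the step seen with the unsubstituted phenyl, so that advantage is not confined to phenyl itself among the compounds shown. Nothing available explains the result for chloro at this place.

Compound 2 and compound 3 both stand at the top of the read-out at a single concentration, so any difference in potency between them remains hidden. Also open, as far as these compounds go, is whether an amine or a carboxylic acid in place of chloro on this ring would hold the read-out at the same level.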